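This account rests on a few compounds, and the source may have more. Where it says the series, first, only, none or still open, it means among the compounds named here.

Measured so far:
compound 1, `N#CC1CN1C(=O)Nc1ccc([N+](=O)[O-])cc1` — 3700 nM in a functional assay on WiDr cells (Homo sapiens) for inhibition; a lower number here means a stronger inhibitor, a higher number a weaker inhibitor
compound 2, `N#CC1CN1C(=O)Nc1ccccc1` — 12000 nM

For the measured compounds named here, compound 2 has the highest number of the two that have been measured; its nearest neighbour is compound 1, which is the only step known for it: a 3.2-fold higher number from compound 1 to compound 2 (0.51 log units; beyond the scatter). Compound 3, `N#CC1CN1C(=O)Nc1ccc(C(F)(F)F)cc1`, is not yet measured. It differs from compound 2 in one place: trifluoromethyl in place of hydrogen on an aromatic carbon. Going by the values given here, the only measured step that bears on this change is the one from compound 1 to compound 2, where taking a group off that same aromatic carbon gave a modestly higher number. Putting a different group back onto that carbon may therefore be expected to move the number in the opposite direction, though the new group is not the one that was removed, so the size is uncertain. The expected step is a 2.2-fold lower number from compound 2 to compound 3 (0.34 log units; beyond the scatter). For compound 3 the estimate in this assay is 5500 nM, with a range from 2000 nM to 15000 nM.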

Compound 3, half-maximal inhibitory concentration: 5800 nM
For compound 3 the middle estimate is 1.1-fold (0.02 log units) below the measured one; the measured number falls inside the stated range.
By their numbers in this assay, from the lowest: compounds 1 and 3 (each within the scatter of the next); then compound 2.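

In this assay, the lower number is not tied to the nitro group alone: trifluoromethyl on the same aromatic carbon, para to the group of 8 heavy atoms, gives a 2.1-fold lower number from compound 2 to compound 3 (0.32 log units; beyond the scatter) and so also improves on the unsubstituted ring of compound 2. Exchanging one group for the other gives a 1.6-fold higher number from compound 1 to compound 3 (0.20 log units; within the scatter) and so leaves nitro and trifluoromethyl indistinguishable in this assay. Nothing measured here explains why either group has this effect.

Two groups on one carbon are too few to give a rule for this position. From the compounds shown here alone, it remains open whether an amine or a carboxylic acid there would also lower the number, or would instead raise it.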